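The source may hold more compounds than are shown below. What is called first, only, known or untested is meant among the compounds shown, and "the series" means these compounds.

Measured compounds:
compound 1, `O=C(Nc1cccc(-c2oc3cc(-c4ccc(F)cc4)ccc3c(=O)c2O)c1)c1ccc(F)cc1`: 16000 nM
compound 2, `Cc1cccc(C(=O)Nc2cccc(-c3oc4cc(-c5ccc(F)cc5)ccc4c(=O)c3O)c2)c1`: 2840 nM

Both compounds were tested in a functional assay on MDA-MB-231 cells (Homo sapiens) for antiproliferative activity, read by CCK-8 assay, with a stated time of 72 h; a higher number here means a weaker inhibitor, a lower number a stronger inhibitor. Compound 1 gives 16000 nM and compound 2 gives 2840 nM. Going by the values given here, of these two numbers, compound 2 holds the lower one, and the single step among the measured compounds, a 5.6-fold lower number from compound 1 to compound 2 (0.75 log units; beyond the scatter), is what separates them.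

Compound 3, `CCCc1ccc(C(=O)Nc2cccc(-c3oc4cc(-c5ccc(F)cc5)ccc4c(=O)c3O)c2)cc1`, has not yet been measured. It differs from compound 2 in one place: 4-propylphenyl in place of 3-methylphenyl on a carbonyl carbon. Among the compounds with values here, this change sits at the same carbonyl carbon where the measured step acted, so a 5.6-fold lower number from compound 1 to compound 2 (0.75 log units; beyond the scatter) is the one step that bears on it, and it shows that exchanging the group on this carbonyl carbon can move the number well beyond the scatter. That step, however, exchanged 4-fluorophenyl for 3-methylphenyl, not 3-methylphenyl for 4-propylphenyl, so it gives no direction for the present change. Within the data shown here, with no closer precedent, the step expected here, a 1.1-fold lower number from compound 2 to compound 3 (0.06 log units; within the scatter), is small and not clearly beyond the scatter. Compound 3 is therefore estimated at 2500 nM, with a range from 800 nM to 8000 nM.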

Compound 3, half-maximal inhibitory concentration: 32200 nM
Compound 3: the middle estimate sits 13-fold (1.11 log units) below what was measured; measured number above the stated range.
By their numbers in this assay, from the lowest: compound 2; then compounds 1 and 3 (each within the scatter of the next).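

In this assay, the group on this carbonyl carbon can also move the number upward: an 11-fold higher number from compound 2 to compound 3 (1.05 log units; beyond the scatter) is a large step, although 3-methylphenyl and 4-propylphenyl are both made of carbon alone and each carries one aromatic ring. So even a change between two such closely related groups is not a small one here, and the earlier step had not shown that this position can lose as well as gain. Compound 1 and compound 3 cannot be told apart, as a 2.0-fold higher number from compound 1 to compound 3 (0.30 log units; within the scatter) lies within the scatter, so among these three compounds only the 3-methylphenyl group of compound 2 stands out, and nothing available gives a reason for this result.

On these data alone, what remains open is whether the number follows the length of the chain on the ring or something else about the group, which an ethyl or a butyl chain in place of the propyl could help to separate. As far as these compounds go, it is also open how this position would respond to a group that is not made of carbon alone, such as an amine or a carboxylic acid on the same ring.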